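The source may hold more compounds than are shown below. What is called first, only, known or untested is meant among the compounds shown, and "the series" means these compounds.

The shared core carries an alkyne linking a six-membered aromatic ring with two nitrogen atoms to a second aromatic ring, and differs only in what sits on that first ring and on the far ring. In an assay on HEK293 cells for positive allosteric modulation of metabotropic glutamate receptor 5 (Rattus norvegicus) (on this read-out lower numbers stand for an effect already at smaller amounts and higher numbers for an effect only at larger amounts of compound), compound 1 `CNc1ncc(C#Cc2ccc(C)cc2)cn1` gives 704000 nM, compound 3 `CNc1ncc(C#Cc2cccc(C)c2)cn1` gives 21100 nM, and compound 2 `CSc1ncc(C#Cc2ccccc2)cn1` gives 120000 nM. Compound 2 therefore stands second highest of the three numbers: its nearest neighbour is compound 3, which sits at a lower number, and its furthest is compound 1, which sits at a higher number; both gaps lie beyond the scatter, so compound 2 is neither the weakest nor the most potent of the three.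

Compound 4 `CC(C)(C)c1ncc(C#Cc2ccccc2)cn1` has not yet been measured in this assay. It differs from compound 2 in one place: tert-butyl in place of methylsulfanyl on an aromatic carbon. Among the measured compounds shown here, no measured pair in this set shows this change, and the three numbers known so far all lie in the weak range. On that basis the expected step is a 1.2-fold lower number from compound 2 to compound 4 (0.08 log units; within the scatter), that is, no movement beyond the scatter in either direction. Compound 4 is accordingly estimated at 100000 nM, with a range from 20000 nM to 500000 nM.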

Compound 4, half-maximal effective concentration: 247000 nM
For compound 4 the middle estimate is 2.5-fold (0.39 log units) below the measured one; the measured number falls inside the stated range.
By their numbers in this assay, from the lowest: compound 3; then compound 2; then compound 4; then compound 1.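

In this assay, the position on an aromatic carbon between two ring nitrogen atoms now has its first comparison in one place, and tert-butyl in place of methylsulfanyl gives a 2.1-fold higher number from compound 2 to compound 4 (0.31 log units; beyond the scatter) with the far ring left unchanged. The change adds to the heavy-atom count, from 2 to 4, removes the sulfur and takes the hydrogen-bond acceptor count from 1 to 0, yet it brings no lower number, and the modest step leaves both compounds in the weak range. With one pair, these differences cannot be separated from one another, and no measurement shown here explains the step.

The compounds shown leave open how this position responds to other groups, such as methoxy, a primary amine or a carboxylic acid, and so whether any group there gives a clearly lower number. They also leave open whether the same change would give a similar step with a methyl group on the far ring, as compound 1 and compound 3 carry, since neither has a partner that differs from it only at this position.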